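Trading an Ether Arm for a Branched Chain

The source may report more compounds than this note shows. Statements on the series, on what has been measured and on what is new or still open speak of the compounds shown alone.

Compound 1 `CCSc1cc(C#N)cc(-c2ccc3ccc(C)nc3c2)c1`: 72 nM
Compound 2 `COCCOc1cc(C#N)cc(-c2ccc3ccc(C)nc3c2)c1`: 82 nM

In a functional assay on CHO cells for inhibition of metabotropic glutamate receptor 5 (Rattus norvegicus), read by FLIPR and calcium flux (a higher number here means a weaker inhibitor, a lower number a stronger inhibitor), compound 1 gives 72 nM, and compound 2 gives 82 nM. Going by the values given here, the only measured step, a 1.1-fold higher number from compound 1 to compound 2 (0.06 log units; within the scatter), leaves the two compounds within the scatter of each other, so compound 2 stands level with compound 1.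

Compound 3 `Cc1ccc2ccc(-c3cc(C#N)cc(OCC(C)C)c3)cc2n1` carries isopropyl in place of methoxymethyl on a saturated chain carbon bound to an oxygen on an aromatic ring. Among the compounds with values here, no measured step touches this part of the chain, so the expectation leans on the near-flat step a 1.1-fold higher number from compound 1 to compound 2 (0.06 log units; within the scatter) alone. No movement beyond the scatter is expected: a 1.2-fold lower number from compound 2 to compound 3 (0.07 log units; within the scatter). Compound 3 is therefore estimated at 70 nM, within 25 nM to 200 nM.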

Compound 3, half-maximal inhibitory concentration: 12000 nM
Compound 3: the middle estimate sits 170-fold (2.23 log units) below what was measured, and the stated range ends below it.
By their numbers in this assay, from the lowest: compounds 1 and 2 (each within the scatter of the next); then compound 3.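

In this assay, isopropyl in place of methoxymethyl on a saturated chain carbon bound to an oxygen on an aromatic ring gives a 150-fold higher number from compound 2 to compound 3 (2.17 log units; beyond the scatter), and isobutoxy in place of ethylsulfanyl gives a 170-fold higher number from compound 1 to compound 3 (2.22 log units; beyond the scatter). So the level pair of ethylsulfanyl and 2-methoxyethoxy did not mean that this place takes any chain, and swapped pieces with equal heavy-atom counts can still differ sharply. Nothing measured here accounts for the loss. Still open, on these data alone, is whether it follows the branching or the lost oxygen. A straight butoxy chain and a 2-hydroxyethoxy arm would help separate the two.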